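Furan-3-yl Analogue in a Growth-Inhibition Series Near Its Limit

A few compounds are considered here, and "the series" means these few. Any claim that something is new, unique, unknown or untested is made for them only; others in the source may bear on it.

Compound 2 `COc1ccc(CNC(=O)/C(C#N)=C/c2cc(Br)co2)cc1` carries a 4-bromofuran-2-yl group on a double-bonded chain carbon bound to a double-bonded chain carbon. In a functional assay on SW480 cells (Homo sapiens) for inhibition, read by MTT assay, with a stated time of 72 h (a lower number here means a stronger inhibitor of growth, a higher number a weaker inhibitor of growth), compound 2 gives only a limit of > 100000 nM, not a measured number. Its measured partner, compound 1 `COc1ccc(CNC(=O)/C(C#N)=C/c2ccc[nH]2)cc1`, bears 1H-pyrrol-2-yl in that place. In this assay compound 1 likewise reaches only a limit, > 50000 nM. The step that the two limits leave unreadable from compound 1 to compound 2 therefore cannot be read, as both values rest at limits the limit of > 100000 nM in this assay, at which 1 of the 2 values shown sits, and (the limit of > 50000 nM in this assay, at which 1 of the 2 values shown sits).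

Compound 3 `COc1ccc(CNC(=O)/C(C#N)=C/c2ccoc2)cc1` differs from compound 2 by furan-3-yl in place of 4-bromofuran-2-yl on a double-bonded chain carbon bound to a double-bonded chain carbon. Going by the values given here, no measured step bears on this change, and the two measured compounds show only that the shared core sits at the edge of this assay. Compound 3 is therefore expected to show a number no higher from compound 2 to compound 3 (the limit leaves the size open), meaning no step beyond the scatter. Compound 3 is estimated at 100000 nM, within 30000 nM to 300000 nM, and is expected most likely to be reported again as a limit.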

Compound 3, concentration for 50% growth inhibition: 8000 nM
Estimate against measurement, compound 3: 13-fold (1.10 log units) above; the whole stated range lies above it.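

In this assay, furan-3-yl on a double-bonded chain carbon bound to a double-bonded chain carbon brings the shared core off the edge of the assay, with an at least 12-fold lower number from compound 2 to compound 3 (1.09 log units; beyond the scatter) and an at least 6.2-fold lower number from compound 1 to compound 3 (0.79 log units; beyond the scatter), so the group at this place can decide whether the series gives a measurable number at all. The first of these steps is only a lower bound because compound 2 stands at a limit: the limit of > 100000 nM in this assay, at which 1 of the 3 values shown sits. The second is likewise a lower bound because compound 1 stands at a limit: the limit of > 50000 nM in this assay, at which 1 of the 3 values shown sits.

The compounds shown do not separate the loss of the bromine from the change from furan-2-yl to furan-3-yl, since compound 3 differs from compound 2 in both respects. Plain furan-2-yl, or furan-3-yl bearing a bromine or an amine, would be needed to tell these apart.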